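Changing the Amide Side of Compound 1

The source may hold more compounds than are shown below. What is called first, only, known or untested is meant among the compounds shown, and "the series" means these compounds.

Among the compounds with values here, in a functional assay on MDA-MB-231 cells (Homo sapiens) for cytotoxicity, read by MTT assay, with a stated time of 72 h (a higher number here means a weaker inhibitor, a lower number a stronger inhibitor), compound 1 `Cc1ccc(F)cc1NC(=O)CN1CCN(c2nnc(Cc3ccccc3)c3ccccc23)CC1` gives 19200 nM, the highest of the two numbers measured so far. Compound 2 `Cc1ccc(F)cc1NC(=O)CN1CCN(c2nnc(Cc3ccncc3)c3ccccc23)CC1` gives 6.4 nM, and pyridin-4-yl in place of phenyl accounts for a 3000-fold lower number from compound 1 to compound 2 (3.48 log units; beyond the scatter).

Compound 3 `O=C(CN1CCN(c2nnc(Cc3ccccc3)c3ccccc23)CC1)Nc1ccc(Br)cc1` keeps that phenyl and changes the other end of the molecule: 4-bromophenyl in place of 5-fluoro-2-methylphenyl on an amide-type nitrogen. It carries 4-bromophenyl in place of 5-fluoro-2-methylphenyl on an amide-type nitrogen. Within the data shown here, no measured step touches that place. Among the measured compounds shown here, the step to compound 2 therefore shows only that numbers can move far, not how far this change will go. With compound 1 at 19200 nM, a modest move towards a lower number in this assay is expected, though it may stay within the scatter. The expected change is a 2.1-fold lower number from compound 1 to compound 3 (0.33 log units; beyond the scatter). For compound 3 the estimated value is 9000 nM, with an expected range from 1500 nM to 40000 nM.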

Compound 3, half-maximal inhibitory concentration: 12400 nM
Beside the measured number, compound 3's estimate is 1.4-fold (0.14 log units) below it; the range from low to high includes it.
By their numbers in this assay, from the lowest: compound 2; then compounds 3 and 1 (each within the scatter of the next).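

In this assay, the swap at the amide end gives a 1.5-fold lower number from compound 1 to compound 3 (0.19 log units; within the scatter), so with the phenyl kept, 4-bromophenyl in place of 5-fluoro-2-methylphenyl on an amide-type nitrogen does not separate the two compounds. Within the data shown here, this is the first reading at this place, and it shows that not every single change moves the number as far as a 3000-fold lower number from compound 1 to compound 2 (3.48 log units; beyond the scatter) does at the other end of the molecule. No other measurement is available to explain this result.

On these data alone, whether 4-bromophenyl would also leave the number within the scatter in a compound carrying pyridin-4-yl remains open, as this swap has been read only with the phenyl in place. Also open, as far as these compounds go, is how a quite different group on the amide-type nitrogen, such as a cyclohexyl ring or a pyridin-3-yl ring, would read in this assay.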